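Swapping Chlorines for Methoxy Groups on a Shared Core

The source may report more compounds than this note shows. Statements on the series, on what has been measured and on what is new or still open speak of the compounds shown alone.

Of the compounds shown here, two built on the same core have so far been tested in a functional assay on DU-145 cells (Homo sapiens) for inhibition, read by sulforhodamine B assay, with a stated time of 48 h; on this read-out higher numbers stand for weaker inhibition of growth and lower numbers for stronger inhibition of growth. Compound 1, `Nc1cc(N)c2nc(-c3ccccc3)c(NCc3ccc(Cl)c(Cl)c3)nc2c1`, gives 16200 nM in this assay. Compound 2, `CCOC(=O)[C@H](CCC(=O)O)NC(=O)c1ccc(Oc2nc3cc(N)cc(N)c3nc2-c2ccccc2)cc1`, gives 5250 nM in this assay. Of these two numbers, compound 1 stands at the higher one, so it is the weaker growth inhibitor of the pair, and compound 2 sits at a number lower by a margin beyond the usual scatter. The two compounds differ in more than one place, so this gap cannot be tied to any single change.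

Compound 3, `COc1ccc(CNc2nc3cc(N)cc(N)c3nc2-c2ccccc2)cc1OC`, has not yet been measured in this assay. It differs from compound 1 in one place: 3,4-dimethoxyphenyl in place of 3,4-dichlorophenyl on a saturated chain carbon bound to a nitrogen on an aromatic ring. Going by the values given here, no pair of measured compounds shows what this exchange does, so the only anchor is the number for compound 1 itself. The step of a 1.2-fold higher number from compound 1 to compound 3 (0.09 log units; within the scatter) is expected to be small, within the usual scatter, with a slight lean toward weaker inhibition. Compound 3 is therefore estimated at 20000 nM, with a plausible range from 6000 nM to 60000 nM.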

Compound 3, concentration for 50% growth inhibition: 460 nM
Compound 3: middle estimate off by 43-fold (1.64 log units), on the high side, and the stated range ends above it.
By their numbers in this assay, from the lowest: compound 3; then compound 2; then compound 1.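

The earlier compounds shown here said nothing about this position, since compound 1 and compound 2 differ in more than one place. Now, in this assay, replacing 3,4-dichlorophenyl with 3,4-dimethoxyphenyl on a saturated chain carbon bound to a nitrogen on an aromatic ring produces a 35-fold lower number from compound 1 to compound 3 (1.55 log units; beyond the scatter) and so much stronger inhibition of growth, showing that on the shared core this one exchange can move the number far beyond the usual scatter. No measurement at hand speaks to the reason for this step.

Both chlorines are exchanged together in this step, so the compounds shown leave open whether a single methoxy group, or one methoxy paired with one chlorine, would give a similar result. They also do not show how the number would respond to a plain phenyl ring at this place, or to a phenyl ring carrying hydroxyl or amine groups where the methoxy groups stand.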